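The source may report more compounds than this note shows. Statements on the series, on what has been measured and on what is new or still open speak of the compounds shown alone.

Three compounds share one core and differ only in the group carried on the saturated chain carbon bound to an aromatic nitrogen. Compound 1 `CCCCCCCCn1cc(CO[C@H]2CC(=O)[C@@H]3OC[C@H]2O3)nn1` bears an octyl chain there; in a functional assay on MDA-MB-231 cells (Homo sapiens) for cytotoxicity, read by MTT assay, with a stated time of 48 h (on this read-out higher numbers stand for weaker inhibition and lower numbers for stronger inhibition), compound 1 reaches only the limit > 50000 nM, which is a limit of the assay and not a number (the limit of > 50000 nM in this assay, at which 1 of the 3 values shown sits). Compound 2 `CCCCn1cc(CO[C@H]2CC(=O)[C@@H]3OC[C@H]2O3)nn1` carries a butyl chain, and in this assay compound 2 gives 27900 nM. Compound 3 `C=C(C)Cn1cc(CO[C@H]2CC(=O)[C@@H]3OC[C@H]2O3)nn1` carries a 1-methylethenyl group, and in this assay compound 3 gives 26700 nM. The step of an at least 1.7-fold lower number from compound 1 to compound 2 (0.25 log units; that floor lies within the scatter) and the step of an at least 1.8-fold lower number from compound 1 to compound 3 (0.27 log units; that floor lies within the scatter) are both bounded by the limit of compound 1, while the step of a 1.0-fold lower number from compound 2 to compound 3 (0.02 log units; within the scatter) is flat. Among the compounds with values here, compound 3 thus stands together with compound 2, the two within the scatter of each other, with the only other value a limit.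

Compound 4 `COc1ccc(Cn2cc(CO[C@H]3CC(=O)[C@@H]4OC[C@H]3O4)nn2)cc1` changes the same position: 4-methoxyphenyl in place of 1-methylethenyl on a saturated chain carbon bound to an aromatic nitrogen. Within the data shown here, the steps that bear on this position, 1>3 and 2>3, were both within the scatter, so no step beyond the scatter is expected in this assay in either direction. Compound 3 to compound 4 is therefore expected to be a 1.1-fold lower number from compound 3 to compound 4 (0.03 log units; within the scatter). For compound 4 the estimate is 25000 nM, within a range from 9000 nM to 60000 nM.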

Compound 4, half-maximal inhibitory concentration: 34800 nM
For compound 4 the middle estimate is 1.4-fold (0.14 log units) below the measured one; the measured number falls inside the stated range.
By their numbers in this assay, from the lowest: compounds 3, 2 and 4 (each within the scatter of the next). At a limit, above all of these: compound 1.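

Putting 4-methoxyphenyl in place of 1-methylethenyl on a saturated chain carbon bound to an aromatic nitrogen gives a 1.3-fold higher number from compound 3 to compound 4 (0.12 log units; within the scatter) in this assay and so shows that a six-membered aromatic ring of carbon only, which none of the earlier groups carried, can sit at this position with no step beyond the scatter. The comparison with the butyl chain gives a 1.2-fold higher number from compound 2 to compound 4 (0.10 log units; within the scatter) and leaves butyl, 1-methylethenyl and 4-methoxyphenyl indistinguishable here, even though the entering group has 8 heavy atoms against 3 for the group it replaces. Against the octyl chain only a floor can be read, an at least 1.4-fold lower number from compound 1 to compound 4 (0.15 log units; that floor lies within the scatter) and compound 1 remains a limit and not a number: the limit of > 50000 nM in this assay, at which 1 of the 4 values shown sits.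

The compounds shown leave open whether an amine or a carboxylic acid on this carbon would give a step beyond the scatter. They also leave open where a chain longer than butyl but shorter than octyl, such as hexyl, would fall, and whether a phenyl group without the methoxy would stand with the other three.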